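The compounds below may be only part of what the source reports. "The series", "measured", "known", "first", "only" and "open" are said of these compounds alone.

Compound 1: `COC(=O)c1ccc(OCc2nc(C)c(C)nc2C)c(OC)c1` — 15.8%
Compound 2: `COc1cc(C(=O)O)ccc1OCc1nc(C)c(C)nc1C` — 18.4%

Both compounds share the same core and were tested in a functional assay on ECV-304 cells (Homo sapiens), read by MTT assay, with stated times of 24 h and 12 h, tested at 50 uM; a higher number here means a stronger effect of the compound at the concentration tested, a lower number a weaker effect. Compound 2 stands at the top of the two numbers, yet only by a number 2.6 percentage points higher from compound 1 to compound 2 (within the scatter), a step that lies within the scatter, so compound 1 and compound 2 cannot be told apart on these data. Among the measured compounds shown here, the single structural change between them is hydrogen in place of methyl on an oxygen next to a carbonyl group.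

Compound 3, `C=CCc1ccc(OCc2nc(C)c(C)nc2C)c(OC)c1`, has not yet been measured in this assay. It differs from compound 2 by allyl in place of carboxy on an aromatic carbon. For the measured compounds named here, the only measured step, from compound 1 to compound 2, also alters the carboxy region and was within the scatter; it does not, however, exchange the carboxy group for an allyl group, so no measured step directly matches this change. With so little to go on, the expected step of a number 1.4 percentage points lower from compound 2 to compound 3 (within the scatter) is small and without a clear direction. The estimate for compound 3 is therefore 17%, with a range from 6% to 32%.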

Compound 3, a percentage reported as activity, at one concentration (the size of the read-out at that concentration, not a potency): 30.1%
For compound 3 the middle estimate is 13.1 percentage points below the measured one, within the range that was stated.
By their numbers in this assay, from the lowest: compounds 1 and 2 (each within the scatter of the next); then compound 3.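

Within this assay, on this aromatic carbon, para to a large group and meta to a methoxy group, putting allyl in place of carboxy gives a number 11.7 percentage points higher from compound 2 to compound 3 (beyond the scatter), and putting allyl in place of methoxycarbonyl gives a number 14.3 percentage points higher from compound 1 to compound 3 (beyond the scatter). The earlier pair changed only the end of the carbonyl-bearing group and could not be told apart, whereas replacing that whole group with an all-carbon chain moves the number beyond the scatter, so this position is not indifferent to what sits on it. Nothing available explains why this exchange raises the number.

The compounds shown leave open whether the rise goes with the loss of the carbonyl-bearing group or with the allyl group itself; a propyl chain, a longer alkenyl chain or an amine at this place would help separate those two readings. They also leave open whether the same order would hold at other concentrations, since each number is the size of an effect at a single concentration and not a potency.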